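The compounds below may be only part of what the source reports. "The series", "measured", "known", "first", "only" and "open" are said of these compounds alone.

Three compounds have been measured so far:

Compound 1, `C=C(C)[C@@H]1CC=C(Cn2cc(COc3cccc(C4NC(=O)NC(C)=C4C(C)=O)c3)nn2)CC1`: 43000 nM
Compound 2, `C=C(C)[C@@H]1CC=C(Cn2cc(COc3cc(C4NC(=O)NC(C)=C4C(C)=O)ccc3OC)nn2)CC1`: a limit of the assay, > 100000 nM
Compound 3, `C=C(C)[C@@H]1CC=C(Cn2cc(COc3ccc(C4NC(=O)NC5=C4C(=O)CC(C)(C)C5)cc3)nn2)CC1`: a limit of the assay, > 100000 nM

All were tested in a functional assay on MCF7 cells (Homo sapiens) for inhibition, read by sulforhodamine B assay, with a stated time of 48 h; on this read-out higher numbers stand for weaker inhibition of growth and lower numbers for stronger inhibition of growth. Compound 1 gives 43000 nM. Compound 2 reaches only a limit of the assay, > 100000 nM. The step of an at least 2.3-fold higher number from compound 1 to compound 2 (0.36 log units; beyond the scatter) goes with a single change: methoxy in place of hydrogen on an aromatic carbon. Compound 3 is built on a different core, and the difference between the two cores is not broken down here. Compound 3 also reaches only a limit of the assay, > 100000 nM. Compound 4, `C=C(C)[C@@H]1CC=C(Cn2cc(COc3ccc(C4NC(=O)NC5=C4C(=O)CC(C)(C)C5)cc3OC)nn2)CC1`, has not been measured yet; it differs from compound 3 by methoxy in place of hydrogen on an aromatic carbon. Going by the values given here, this is the same kind of change as the one from compound 1 to compound 2, though around the place the incoming methoxy in compound 4 is meta to a large group rather than para to one. Since compound 3 already sits at the limit of > 100000 nM in this assay, at which 2 of the 3 values shown sit, compound 4 is expected to remain there as well, with an expected step that the limit leaves unreadable from compound 3 to compound 4. Compound 4 is therefore estimated at 150000 nM.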

Compound 4, concentration for total growth inhibition: 91900 nM
The estimate for compound 4 lay 1.6-fold (0.21 log units) above the measured number, and the stated range covers the measured number.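

In this assay, methoxy in place of hydrogen on an aromatic carbon goes with an at least 1.0-fold lower number from compound 3 to compound 4 (0.03 log units; that floor lies within the scatter). Set beside the earlier case, the same change reads as follows: the same change on two cores in this assay, an at least 2.3-fold higher number (0.36 log units; beyond the scatter) from compound 1 to compound 2 and an at least 1.0-fold lower number (0.03 log units; that floor lies within the scatter) from compound 3 to compound 4; the limit leaves it open whether they differ. So the drop in growth inhibition seen on the core of compound 1 is not shown to repeat on the core of compound 3, but a true difference between the two cores is not shown either, and the limits leave the real size of both steps unknown.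

The compounds shown leave open how a hydroxyl group or a longer chain such as ethoxy would behave on this aromatic carbon. They also leave open whether either core can give clearly stronger inhibition of growth.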